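A few compounds are considered here, and "the series" means these few. Any claim that something is new, unique, unknown or untested is made for them only; others in the source may bear on it.

For the measured compounds named here, in a functional assay on the whole organism for inhibition, with Mus musculus as the target (on this read-out higher numbers stand for an effect only at larger amounts of compound and lower numbers for an effect already at smaller amounts), compound 1 `CN1Cc2c(N)cccc2C(c2ccc(Cl)cc2)C1` gives 1.1 mg/kg, the lower of the two numbers measured so far. Compound 2 `CC(C)c1ccc(C2CN(C)Cc3c(N)cccc32)cc1` gives 68 mg/kg. The step between them, a 62-fold higher number from compound 1 to compound 2 (1.79 log units; beyond the scatter), is large and beyond the scatter, and it comes from isopropyl taking the place of chloro on an aromatic carbon. Compound 3 `CCCCNCC(=O)Nc1cccc2c1CN(C)CC2c1ccc(Cl)cc1` keeps that chloro and differs at another place: ((butylamino)methyl)carbonyl in place of hydrogen on a nitrogen on an aromatic ring. Here ((butylamino)methyl)carbonyl stands in place of hydrogen on a nitrogen on an aromatic ring. Going by the values given here, no measured step covers a change on this nitrogen, so the data offer only a weak guide. Among the compounds with values here, the one step available, a 62-fold higher number from compound 1 to compound 2 (1.79 log units; beyond the scatter), shows only that a single change can move the number far. A moderate rise is expected, and the expected step is a 4.5-fold higher number from compound 1 to compound 3 (0.66 log units; beyond the scatter). For compound 3 the estimated value is 5 mg/kg, with an expected range from 1.2 mg/kg to 25 mg/kg.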

Compound 3, dose for half-maximal effect: 3.9 mg/kg
Beside the measured number, compound 3's estimate is 1.3-fold (0.11 log units) above it; the measured number falls inside the stated range.
By their numbers in this assay, from the lowest: compound 1; then compound 3; then compound 2.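

On the nitrogen on an aromatic ring, ((butylamino)methyl)carbonyl in place of hydrogen gives a 3.5-fold higher number from compound 1 to compound 3 (0.55 log units; beyond the scatter) in this assay, and this first step at this position is modest. The amino group of compound 1 can therefore be replaced by the much larger (((butylamino)methyl)carbonyl)amino with a far smaller change in the number than the large step of a 62-fold higher number from compound 1 to compound 2 (1.79 log units; beyond the scatter) brought on the aromatic carbon. Nothing available here accounts for the modest rise in compound 3.

The compounds shown leave open whether the rise belongs to the carbonyl on the nitrogen or to the butylamino part, which a plain acetyl group would help to separate. They also leave open how a shorter amine such as dimethylamino, or a longer chain such as hexylamino, would read in place of butylamino.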